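A few compounds are considered here, and "the series" means these few. Any claim that something is new, unique, unknown or untested is made for them only; others in the source may bear on it.

In a functional assay (aorta) for inhibition, with Rattus norvegicus as the target (a lower number here means a stronger inhibitor, a higher number a weaker inhibitor), compound 1 `Oc1nc(NCC2CCCCC2)nc2ccc(Cl)cc12` gives 2200 nM, while compound 2 `C[C@@H](Nc1nc(O)c2cc(Cl)ccc2n1)C1CCCCC1` gives 5600 nM, the higher of the two numbers. Going by the values given here, the only measured step, a 2.5-fold higher number from compound 1 to compound 2 (0.41 log units; beyond the scatter), concerns a methyl group and tells nothing about handedness. Compound 3 `C[C@H](Nc1nc(O)c2cc(Cl)ccc2n1)C1CCCCC1` differs from compound 2 in that (the two compounds have the same atoms and bonds and differ only in configuration as drawn: 1 of 1 stereo elements differ; a stereocentre at a saturated chain carbon is drawn R in compound 2 and S in compound 3). Among the compounds with values here, no measured step bears on such a change, so the direction is open, and mirror-image forms can sit either way. Compound 3 is therefore expected to give about 3000 nM, with a wide range from 600 nM to 15000 nM. That estimate corresponds to an expected step of a 1.9-fold lower number from compound 2 to compound 3 (0.27 log units; within the scatter).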

Compound 3, half-maximal inhibitory concentration: 2100 nM
Beside the measured number, compound 3's estimate is 1.4-fold (0.15 log units) above it, within the range that was stated.
By their numbers in this assay, from the lowest: compounds 3 and 1 (each within the scatter of the next); then compound 2.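

In this assay, handedness at this saturated chain carbon matters: a 2.7-fold lower number from compound 2 to compound 3 (0.43 log units; beyond the scatter). With the methyl drawn S, the number cannot be told apart from that of the compound without a methyl: a 1.0-fold lower number from compound 1 to compound 3 (0.02 log units; within the scatter). The rise seen earlier on adding the methyl therefore belongs to the R form only, and configuration alone can account for the gap between the two forms, because of this: the fact that compounds 2 and 3 differ only in the configuration as drawn. As far as these compounds go, whether a larger branch at this carbon, such as an ethyl or a hydroxymethyl group, would show the same split between R and S remains open.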